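A few compounds are considered here, and "the series" means these few. Any claim that something is new, unique, unknown or untested is made for them only; others in the source may bear on it.

In a functional assay on FaDu cells (Homo sapiens) for antiproliferative activity, read by sulforhodamine B assay, with a stated time of 48 h (a lower number here means a stronger inhibitor, a higher number a weaker inhibitor), compound 1 (`COc1ccc(-c2oc3c(OC)c(OC)cc(OCCCCC(=O)NCc4ccccn4)c3c(=O)c2O)cc1`) gives > 40000 nM, which is a limit of the assay. Compound 2 (`COc1ccc(-c2oc3c(OC)c(OC)cc(OCCCCC(=O)N4CCN(C)CC4)c3c(=O)c2O)cc1`) gives > 40000 nM, also only a limit, so its standing has no number; (the limit of > 40000 nM in this assay, at which 2 of the 2 values shown sit). Compound 3 (`COc1ccc(-c2oc3c(OC)c(OC)cc(OCCCCCC(=O)NCc4ccccn4)c3c(=O)c2O)cc1`) has (((pyridin-2-yl)methyl)carbamoyl)methyl in place of (4-methylpiperazin-1-yl)carbonyl on a saturated chain carbon, four bonds along the chain from an oxygen on an aromatic ring. Within the data shown here, the only measured step that bears on this is a step that the two limits leave unreadable from compound 1 to compound 2, and it offers no size to carry over. The expected change in this assay is therefore small, with an estimated a number no higher from compound 2 to compound 3 (the limit leaves the size open). Compound 3 is expected near 40000 nM, within an estimated range of 15000 nM to 60000 nM.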

Compound 3, half-maximal inhibitory concentration: > 40000 nM
Compound 3 was reported as a limit; the forecaster's own chance of this, stated with the estimate: 70%; the middle value lies on the limit itself.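

In this assay compound 3 gives > 40000 nM, a limit, so no step linking it to compound 1 or compound 2 can be read: the limit of > 40000 nM in this assay, at which 3 of the 3 values shown sit.

The compounds shown leave open how strong each one is and whether any of these changes affects activity.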